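Sulfonyl substituent and microsomal stability in the series

The source may hold more compounds than are shown below. What is called first, only, known or untested is meant among the compounds shown, and "the series" means these compounds.

Three compounds share one core and differ only at the sulfonyl sulfur or on the ring attached to it. Compound 1 `O=C(NS(=O)(=O)c1ccc(F)cc1)c1ccc(Nc2nc(NC3(c4ccc(Cl)cc4)CC3)nc(OCC(F)(F)F)n2)cc1` gives 99% in an ADME assay on microsomes from liver (Rattus norvegicus) for metabolic stability, with a stated time of 10 min; on this read-out lower numbers stand for a less stable compound and higher numbers for a more stable compound. Compound 2 `CC(C)OC(=O)NCCS(=O)(=O)NC(=O)c1ccc(Nc2nc(NC3(c4ccc(Cl)cc4)CC3)nc(OCC(F)(F)F)n2)cc1` gives 73% in this assay. Compound 3 `O=C(NS(=O)(=O)c1ccccc1)c1ccc(Nc2nc(NC3(c4ccc(Cl)cc4)CC3)nc(OCC(F)(F)F)n2)cc1` gives 100% in this assay and holds the highest of the three numbers; its gap to compound 1 lies within the scatter, while the step of a number 27 percentage points higher from compound 2 to compound 3 (beyond the scatter) lies beyond it. Compound 4 `CNC(=O)NCCS(=O)(=O)NC(=O)c1ccc(Nc2nc(NC3(c4ccc(Cl)cc4)CC3)nc(OCC(F)(F)F)n2)cc1` is not yet measured. The change is 2-((methylcarbamoyl)amino)ethyl in place of phenyl on a sulfonyl sulfur. Among the measured compounds shown here, two measured steps bear on this exchange, both at the sulfonyl sulfur: a number 26 percentage points lower from compound 1 to compound 2 (beyond the scatter) and a number 27 percentage points higher from compound 2 to compound 3 (beyond the scatter). In both, a phenyl or fluorophenyl group on the sulfonyl sulfur went with the higher number and the 2-((isopropoxycarbonyl)amino)ethyl chain with the lower. For the measured compounds named here, compound 4 carries a 2-((methylcarbamoyl)amino)ethyl chain at the same place; no measured compound holds such a chain there, so the two steps above are the only guide. A modest drop of roughly the same size is therefore expected in this assay, the expected step being a number 28 percentage points lower from compound 3 to compound 4 (beyond the scatter). For compound 4 the estimate is 72%, within the range 50% to 92%.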

Compound 4, percent of the compound remaining: 100%
The estimate for compound 4 lay 28 percentage points below the measured number; the whole stated range lies below it.
By their numbers in this assay, from the lowest: compound 2; then compounds 1, 3 and 4 (each within the scatter of the next).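

Working notes on the sulfonyl position: in this assay, a chain on the sulfonyl sulfur does not by itself go with the lower number, since the 2-((methylcarbamoyl)amino)ethyl chain gives no change at the digits printed from compound 3 to compound 4 (within the scatter) and a number 1 percentage points higher from compound 1 to compound 4 (within the scatter) even though it has no ring in place of the aromatic ring of phenyl or 4-fluorophenyl. The earlier drop therefore cannot be read as a general contrast between aryl groups and chains at this position, as the change of methylamino in place of isopropoxy on a carbonyl carbon gives a number 27 percentage points higher from compound 2 to compound 4 (beyond the scatter) and, of the four compounds, compound 2 alone stands apart. No supporting data on hand explain the difference between these two chains.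

The compounds shown leave open whether the lower number follows the isopropoxy group itself or its pairing with this chain, which an ethoxy or tert-butoxy carbamate, or a dimethylamino urea, on the same ethyl chain would test. They also leave open how far the position tolerates other groups, such as a longer chain ending in the methyl urea, a primary amine or a carboxylic acid.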